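The compounds below may be only part of what the source reports. "The series", "measured", "known", "first", "only" and "open" are said of these compounds alone.

Series notes. Compound 1 `CCOC(=O)c1cccc(-c2ccc(OCC)cc2)c1` gives 87% in an assay on COS-7 cells for inhibition of patatin-like phospholipase domain-containing protein 2 (Mus musculus), tested at 200 uM; a lower number here means less inhibition, a higher number more inhibition at the concentration tested (going by the name of the read-out); compound 2 `CCOC(=O)c1cccc(-c2ccc(OC)cc2)c1` gives 77%; compound 3 `CCOc1ccc(-c2cccc(C(=O)NC)c2)cc1` gives 40%. The change methyl in place of hydrogen on a saturated chain carbon bound to an oxygen on an aromatic ring gives the step of a number 10 percentage points higher from compound 2 to compound 1 (within the scatter). The change a number 47 percentage points lower from compound 1 to compound 3 (beyond the scatter) is large. Compound 4 `CCNC(=O)c1cccc(-c2ccc(OCC)cc2)c1` is not yet measured; it differs from compound 3 by methyl in place of hydrogen on a saturated chain carbon bound to an amide-type nitrogen. This is the same kind of change as in compound 2 to compound 1, but the place differs: there on a saturated chain carbon bound to an oxygen on an aromatic ring, here on a saturated chain carbon bound to an amide-type nitrogen. The difference between the cores of compound 3 and compound 2 is not broken down here. Because the earlier step of a number 10 percentage points higher from compound 2 to compound 1 (within the scatter) lay within the scatter, a similar small step is expected, a number 8 percentage points higher from compound 3 to compound 4 (within the scatter). Compound 4 is estimated at 48%, between 30% and 65%.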

Compound 4, a percentage reported as inhibition, at one concentration (the size of the read-out at that concentration, not a potency): 62%
Beside the measured number, compound 4's estimate is 14 percentage points below it; the measured number falls inside the stated range.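

In this assay, methyl in place of hydrogen on a saturated chain carbon bound to an amide-type nitrogen gives a number 22 percentage points higher from compound 3 to compound 4 (beyond the scatter), and the comparison with the earlier step reads: the same change on two cores in this assay, a number 10 percentage points higher (within the scatter) from compound 2 to compound 1 and a number 22 percentage points higher (beyond the scatter) from compound 3 to compound 4, 12 percentage points apart, within the scatter of two such steps. No difference in this change can be claimed for the two cores, but with one pair on each core, this does not show that the step would hold on any other core. Even with the added methyl, replacing the ester with the amide gives a number 25 percentage points lower from compound 1 to compound 4 (beyond the scatter).

The compounds shown leave open how a longer chain on the amide-type nitrogen would read. On these data alone, a carboxylic acid in place of the ethyl ester of compound 1 also remains open.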